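A Pyridin-2-yl Swap Carried Across Two Related Cores

The source may hold more compounds than are shown below. What is called first, only, known or untested is meant among the compounds shown, and "the series" means these compounds.

The study covers four compounds built on two related cores. Compound 1 `Cn1nc(N)c2c(=O)[nH]c(-c3ccccc3)cc21` carries a phenyl group, and compound 2 `Cn1nc(N)c2c(=O)[nH]c(-c3ccccn3)cc21` has pyridin-2-yl in its place, the change being (pyridin-2-yl in place of phenyl on an aromatic carbon). Compound 3 `Nc1c2c(=O)[nH]c(-c3ccccc3)cc2nn1-c1ccccc1` differs from compound 1 in the core itself; the difference between the two cores is not broken down here. Compound 4 `Nc1c2c(=O)[nH]c(-c3ccccn3)cc2nn1-c1ccccc1` is the pyridin-2-yl counterpart of compound 3 and has not yet been measured.

In an assay on isolated protein for inhibition of serine/threonine-protein kinase D2 (Homo sapiens), read by mobility shift assay, tested at 30 uM (a higher number here means more inhibition at the concentration tested (going by the name of the read-out), a lower number less inhibition), compound 1 gives 14%, and compound 2 gives 17%, a step of a number 3 percentage points higher from compound 1 to compound 2 (within the scatter). In this assay compound 3 gives 23%, a number that lies within the scatter of the values of compound 1 and compound 2.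

The change from compound 3 to compound 4, (pyridin-2-yl in place of phenyl on an aromatic carbon), is the same change as that from compound 1 to compound 2. Because the earlier step was a number 3 percentage points higher from compound 1 to compound 2 (within the scatter), a step of similar small size is expected, a number 3 percentage points higher from compound 3 to compound 4 (within the scatter). Compound 4 is therefore estimated at 26% in this assay, expected to fall between 12% and 40%.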

Compound 4, a percentage reported as inhibition, at one concentration (the size of the read-out at that concentration, not a potency): 15%
The estimate for compound 4 lay 11 percentage points above the measured number; measured number inside the range.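

In this assay the change from phenyl to pyridin-2-yl on the second core gives a number 8 percentage points lower from compound 3 to compound 4 (within the scatter). Set beside the earlier step, the change reads the same on both cores: the same change on two cores in this assay, a number 3 percentage points higher (within the scatter) from compound 1 to compound 2 and a number 8 percentage points lower (within the scatter) from compound 3 to compound 4, 11 percentage points apart, within the scatter of two such steps. Nothing here therefore speaks against carrying the change from one core to the other, but this is weak support: neither step stands out from the scatter, so the pair shows only that no effect of the change can be read on either core at this one tested concentration, not that a real effect passes from core to core.

The compounds shown leave open whether the change would behave alike on the two cores in a series where it gave a step beyond the scatter. They also leave open how the read-out would respond to a different kind of group on the pyridin-2-yl ring, such as an amine or a carboxylic acid.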